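Sulfur-linked benzoxazole swapped for oxygen-linked isoquinoline

This account rests on a few compounds, and the source may have more. Where it says the series, first, only, none or still open, it means among the compounds named here.

Compound 2 `CC(C)[C@H](NC(=O)COc1cccc2ccccc12)C(=O)N[C@@H](CC(=O)O)C(=O)CSc1nc2ccccc2o1` is one of two close relatives tested in a functional assay on Jurkat cells (Homo sapiens) for inhibition; on this read-out lower numbers stand for stronger inhibition and higher numbers for weaker inhibition. For compound 2 the read-out is only a limit, > 200000 nM, so compound 2 sits at the limit of > 200000 nM in this assay, at which 1 of the 2 values shown sits, rather than at a number. Its partner compound 1 `CC(C)[C@H](NC(=O)COc1cccc2ccccc12)C(=O)N[C@@H](CC(=O)O)C(=O)CSc1nnc(-c2ccccc2)o1` gives 150000 nM, and the step of an at least 1.3-fold higher number from compound 1 to compound 2 (0.12 log units; that floor lies within the scatter) is the only measured one. Compound 3 `CC(C)[C@H](NC(=O)COc1cccc2ccccc12)C(=O)N[C@@H](CC(=O)O)C(=O)COc1nccc2ccccc12` arises from compound 2 by (isoquinolin-1-yl)oxy in place of (1,3-benzoxazol-2-yl)sulfanyl on a saturated chain carbon bound to a carbonyl carbon. Going by the values given here, no measured step touches the link atom itself, and the one known step stays within the scatter, so for a number no higher from compound 2 to compound 3 (the limit leaves the size open) no change beyond the scatter is expected. Compound 3 is therefore expected near 200000 nM, between 60000 nM and 600000 nM, and may again be reported only as a limit.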

Compound 3, half-maximal inhibitory concentration: 106000 nM
Compound 3: the middle estimate sits 1.9-fold (0.28 log units) above what was measured, and the stated range covers the measured number.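

Replacing the sulfur-linked ring with (isoquinolin-1-yl)oxy on this saturated chain carbon gives a compound that can be read as a number in this assay, with an at least 1.8-fold lower number from compound 2 to compound 3 (0.27 log units; that floor lies within the scatter). Against the other sulfur-linked compound, there is a 1.4-fold lower number from compound 1 to compound 3 (0.15 log units; within the scatter), so this change shows no real gain or loss in potency. Compound 2 is reported only as a limit, so its step has only a floor: the limit of > 200000 nM in this assay, at which 1 of the 3 values shown sits.

As far as these compounds go, the link atom and the ring change together in compound 3, so their separate shares stay open. Also open, from the compounds shown here alone, is how (isoquinolin-1-yl)sulfanyl, or an amine as the link, would read here.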